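The compounds below may be only part of what the source reports. "The series", "measured", "known", "first", "only" and "open" are said of these compounds alone.

Working notes on the series.

Three esters built on the shared core have been measured in a functional assay on liver (Rattus norvegicus, strain Sprague-Dawley) for inhibition, with a stated time of 1 h; a higher number here means a weaker inhibitor, a lower number a stronger inhibitor. Compound 1 `CCOC(=O)CC(=O)OCC1Oc2ccc([C@H]3Oc4cc(O)cc(O)c4C(=O)[C@@H]3O)cc2OC1c1ccc(O)c(OC)c1` gives 33400 nM. Compound 2 `COc1cc(C2Oc3cc([C@H]4Oc5cc(O)cc(O)c5C(=O)[C@@H]4O)ccc3OC2COC(=O)c2ccc([N+](=O)[O-])cc2)ccc1O` gives 12600 nM, and compound 3 `COc1cc(C2Oc3cc([C@H]4Oc5cc(O)cc(O)c5C(=O)[C@@H]4O)ccc3OC2COC(=O)c2ccc(N)cc2)ccc1O` gives 14300 nM. The two aryl esters sit close together: a 1.1-fold higher number from compound 2 to compound 3 (0.05 log units; within the scatter), so nothing separates compound 2 from compound 3 on these numbers. Against compound 1 both lie lower: a 2.7-fold lower number from compound 1 to compound 2 (0.42 log units; beyond the scatter) and a 2.3-fold lower number from compound 1 to compound 3 (0.37 log units; beyond the scatter). Compound 3 therefore stands second of the three numbers, within the scatter of compound 2 and beyond it only against compound 1.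

The next compound, compound 4 `COc1cc(C2Oc3cc([C@H]4Oc5cc(O)cc(O)c5C(=O)[C@@H]4O)ccc3OC2COC(=O)/C=C/c2ccc(Br)cc2)ccc1O`, differs from compound 3 in one place: 2-(4-bromophenyl)ethenyl in place of 4-aminophenyl on a carbonyl carbon. Within the data shown here, no measured step covers this change directly. What bears on it is that the two replacements of (ethoxycarbonyl)methyl by an aryl group each gave a modest lowering, while swapping amino for nitro gave nothing beyond the scatter, which suggests that the identity of the group on the carbonyl carbon moves this assay only a little. Compound 4 is thus expected to stay near compound 3, with at most a small step, a 1.3-fold lower number from compound 3 to compound 4 (0.11 log units; within the scatter), in either direction. The estimate for compound 4 in this assay is 11000 nM, with a range from 4000 nM to 30000 nM.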

Compound 4, half-maximal inhibitory concentration: 16300 nM
For compound 4 the middle estimate is 1.5-fold (0.17 log units) below the measured one; the measured number falls inside the stated range.
By their numbers in this assay, from the lowest: compounds 2, 3 and 4 (each within the scatter of the next); then compound 1.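

The change from 4-aminophenyl to 2-(4-bromophenyl)ethenyl on the carbonyl carbon alters more than the ring substituent: bromine enters, amino leaves, and a double bond outside aromatic rings is added, yet in this assay there is a 1.1-fold higher number from compound 3 to compound 4 (0.06 log units; within the scatter) and a 1.3-fold higher number from compound 2 to compound 4 (0.11 log units; within the scatter). This position therefore tolerates a group of a different shape and a different ring substituent without any step beyond the scatter among compounds 2, 3 and 4. The lower number relative to the ester with (ethoxycarbonyl)methyl also holds for this third aryl-bearing group, with a 2.0-fold lower number from compound 1 to compound 4 (0.31 log units; beyond the scatter), so all three aryl-bearing groups now stand lower than compound 1 by a modest margin; no measurement available here accounts for either observation.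

The step to compound 4 changes the double bond and the ring substituent together, so a 2-(4-aminophenyl)ethenyl group would be needed to separate the two. From the compounds shown here alone, it also remains open how the number responds on this carbonyl carbon to a plain alkyl chain such as hexyl, to a group ending in a carboxylic acid, or to a free hydroxymethyl group in place of the ester.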